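The compounds below may be only part of what the source reports. "The series", "measured", "known", "first", "only" and "open" are said of these compounds alone.

The measured compounds in the series:

Compound 1 `CNc1nc(C)c(C(=O)N/N=C/c2cc(C(F)(F)F)cc(C(F)(F)F)c2)s1`: > 100 ug/mL
Compound 2 `CN(C(=O)NC(=O)c1ccc(F)c(F)c1)c1nc(C(F)(F)F)c(C(=O)N/N=C/c2cc(C(F)(F)F)cc(C(F)(F)F)c2)s1`: 4.45 ug/mL
Compound 3 `CNc1nc(C(F)(F)F)c(C(=O)N/N=C/c2cccc(C(F)(F)F)c2)s1`: > 100 ug/mL

In a functional assay on HeLa cells (Homo sapiens) for inhibition, read by MTT assay, with a stated time of 72 h (on this read-out higher numbers stand for weaker inhibition and lower numbers for stronger inhibition), compound 2 gives 4.45 ug/mL, the only numerical result here. Compound 1 reaches only the assay limit at > 100 ug/mL. Compound 3 likewise stops at the limit, > 100 ug/mL. The remaining results thus sit at the limit of > 100 ug/mL in this assay, at which 2 of the 3 values shown sit. Compound 4 `CN(C(=O)NC(=O)c1ccc(C(F)(F)F)cc1)c1nc(C(F)(F)F)c(C(=O)N/N=C/c2cc(C(F)(F)F)cc(C(F)(F)F)c2)s1` differs from compound 2 by 4-(trifluoromethyl)phenyl in place of 3,4-difluorophenyl on a carbonyl carbon. Among the compounds with values here, no measured pair separated by one change is available, so the step cannot be gauged from precedent; the expectation is that the step from compound 2 to compound 4 stays within the usual scatter, namely a 1.0-fold higher number from compound 2 to compound 4 (0.00 log units; within the scatter). Compound 4 is therefore estimated at 4.5 ug/mL, within a range from 1.5 ug/mL to 15 ug/mL.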

Compound 4, half-maximal inhibitory concentration: 5.78 ug/mL
For compound 4 the middle estimate is 1.3-fold (0.11 log units) below the measured one; measured number inside the range.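

In this assay, within the data shown here, replacing 3,4-difluorophenyl with 4-(trifluoromethyl)phenyl on a carbonyl carbon gives a 1.3-fold higher number from compound 2 to compound 4 (0.11 log units; within the scatter), the first step that can be read at this place. At this place, then, these two aromatic groups give results that cannot be told apart, although their heavy-atom counts differ. Nothing shown here gives a cause for this result. Both groups are fluorinated phenyl rings, so the step says nothing about how an unsubstituted phenyl, a carboxylic acid or a longer alkyl chain would read at this place.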